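A few compounds are considered here, and "the series" means these few. Any claim that something is new, unique, unknown or untested is made for them only; others in the source may bear on it.

Three compounds sharing one core have numbers in a functional assay on FM3A cells (Mus musculus) for cytotoxicity; on this read-out higher numbers stand for an effect only at larger amounts of compound and lower numbers for an effect already at smaller amounts. Compound 1 (`C=C(C)COOC1(OOC)CCCCCCCCCCC1`) gives 17000 nM and compound 2 (`CCCCOOC1(OOC)CCCCCCCCCCC1`) gives 20000 nM. The measured step between them, a 1.2-fold higher number from compound 1 to compound 2 (0.07 log units; within the scatter), separates them by no more than the usual scatter. Compound 3 (`COOC1(OOCCCCCCI)CCCCCCCCCCC1`) stands highest of the three at 86000 nM, reached by a 5.1-fold higher number from compound 1 to compound 3 (0.70 log units; beyond the scatter) and by a 4.3-fold higher number from compound 2 to compound 3 (0.63 log units; beyond the scatter).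

Compound 4 (`CCOC(C)OOC1(OOC)CCCCCCCCCCC1`) has no number yet. It differs from compound 3 in having 1-ethoxyethyl in place of 6-iodohexyl on an oxygen. For the measured compounds named here, no measured step makes this exchange, and no measured compound carries 1-ethoxyethyl, so the evidence is indirect. Compound 1 and compound 2 are the closest guides, as neither carries iodine. The exchange removes the iodine-bearing chain of compound 3, so it may undo a step of the size of a 4.3-fold higher number from compound 2 to compound 3 (0.63 log units; beyond the scatter). A modest step toward a lower number is therefore expected, though the reversal is not certain. The step expected in this assay is a 3.4-fold lower number from compound 3 to compound 4 (0.54 log units; beyond the scatter). Compound 4 is estimated at 25000 nM, with an expected range from 8000 nM to 80000 nM.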

Compound 4, half-maximal effective concentration: 12000 nM
Compound 4: the middle estimate sits 2.1-fold (0.32 log units) above what was measured; low and high end bracket the measured number.
By their numbers in this assay, from the lowest: compounds 4, 1 and 2 (each within the scatter of the next); then compound 3.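

In this assay, putting 1-ethoxyethyl in place of 6-iodohexyl on this oxygen gives a 7.2-fold lower number from compound 3 to compound 4 (0.86 log units; beyond the scatter) and so shows directly, in a single exchange at this place, that the group on the oxygen can move the number beyond the scatter. Set against the two groups without iodine, the same position shows little: 1-ethoxyethyl gives a 1.7-fold lower number from compound 2 to compound 4 (0.22 log units; within the scatter) against butyl and a 1.4-fold lower number from compound 1 to compound 4 (0.15 log units; within the scatter) against 2-methylprop-2-en-1-yl, so a group with an oxygen and one hydrogen-bond acceptor stands with those two hydrocarbon groups, and among these four compounds only compound 3 stands apart. Nothing given here accounts for why compound 3 stands apart.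

The compounds shown cannot separate the iodine from the length of the chain, since a plain hexyl chain or a shorter iodine-bearing chain would be needed to tell which of the two goes with the higher number. From the compounds shown here alone, how an amine or a carboxylic acid would read in place of these groups on the oxygen also remains open.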